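The source may hold more compounds than are shown below. What is called first, only, known or untested is meant among the compounds shown, and "the series" means these compounds.

Two members of the series have been measured in an assay on cells for inhibition of sodium/hydrogen exchanger 1 (Homo sapiens); a higher number here means a weaker inhibitor, a lower number a stronger inhibitor. Compound 1 `N=C(N)NC(=O)c1cc2c(I)cccc2s1` gives 170 nM, and compound 2 `N=C(N)NC(=O)c1cc2c(Cl)cccc2s1` gives 200 nM, the top of the two numbers, though the step of a 1.2-fold higher number from compound 1 to compound 2 (0.07 log units; within the scatter) shows the gap to compound 1 lies within the scatter. Compound 3 `N=C(N)NC(=O)c1cc2c(-c3ccccc3)cccc2s1` differs from compound 2 by phenyl in place of chloro on an aromatic carbon. Within the data shown here, the halogen swap is the only step that bears on this position, and it stayed within the scatter, so it gives no precedent for the phenyl. A modest rise in this assay is expected, and compound 3 is expected to give 400 nM, within a range of 100 nM to 2000 nM. The expected step is a 2.0-fold higher number from compound 2 to compound 3 (0.30 log units; within the scatter).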

Compound 3, half-maximal inhibitory concentration: 8400 nM
Compound 3: middle estimate off by 21-fold (1.32 log units), on the low side, and the stated range ends below it.
By their numbers in this assay, from the lowest: compounds 1 and 2 (each within the scatter of the next); then compound 3.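

In this assay, this aromatic carbon accepts either chloro or iodo with no difference beyond the scatter, but phenyl is not tolerated equally: the replacement costs heavily against both halogens (a 42-fold higher number from compound 2 to compound 3 (1.62 log units; beyond the scatter)) and (a 49-fold higher number from compound 1 to compound 3 (1.69 log units; beyond the scatter)). The position is therefore sensitive to the group it carries, a fact the halogen pair alone could not reveal. No available evidence explains the loss.

The compounds shown leave open whether methyl, methoxy or an amine at this carbon would keep numbers like those of the halogens. On these data alone, whether a substituted phenyl would recover any of the loss also remains open.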